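The source may hold more compounds than are shown below. What is called first, only, known or untested is meant among the compounds shown, and "the series" means these compounds.

Compound 1 `Brc1ccc(Nc2nc(/C=C/c3ccccc3)nc3ccsc23)cc1`: > 1000000 nM (a limit)
Compound 2 `Brc1cccc(Nc2nc(/C=C/c3ccccc3)nc3ccsc23)c1`: > 1000000 nM (a limit)

In a functional assay on L02 cells (Homo sapiens) for inhibition, read by Griess assay, with stated times of 1 h and 24 h (on this read-out higher numbers stand for weaker inhibition and lower numbers for stronger inhibition), compound 2 gives > 1000000 nM, which is a limit of the assay and not a number. Within the data shown here, the same holds for every compound measured so far: the limit of > 1000000 nM in this assay, at which 2 of the 2 values shown sit. Among the measured compounds shown here, compound 2 therefore has no exact position, and the data show no stronger compound to compare it with.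

Compound 3 `Fc1ccc(CNc2nc(/C=C/c3ccccc3)nc3ccsc23)cc1` carries 4-fluorobenzyl in place of 3-bromophenyl on a nitrogen on an aromatic ring.

For the measured compounds named here, only one measured step bears on this change, a step that the two limits leave unreadable from compound 1 to compound 2, where 3-bromophenyl stands in place of 4-bromophenyl on the same nitrogen. Going by the values given here, it offers no size to carry over, and no measured compound has a 4-fluorobenzyl group. The expectation therefore stays anchored on compound 2 at > 1000000 nM, with no step beyond the scatter expected in this assay and no direction favoured. A further limit is the likeliest report.

For compound 3 the expected value is 1000000 nM, with an estimated range from 200000 nM to 3000000 nM.

The estimated step is a number no higher from compound 2 to compound 3 (the limit leaves the size open).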

Compound 3, half-maximal inhibitory concentration: > 1000000 nM
Compound 3: no number, only a limit (the forecaster's own chance of this, stated with the estimate: 70%); the middle value sits exactly at the limit.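

In this assay compound 3 gives > 1000000 nM, which is a limit and not a number. The steps linking compound 1, compound 2 and compound 3 therefore cannot be read. The compounds shown leave open whether any group on this nitrogen gives a measurable inhibition, and all that they show is one shared result: the limit of > 1000000 nM in this assay, at which 3 of the 3 values shown sit.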